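Removing the para-fluoro from a piperazine sulfonamide xanthine

A few compounds are considered here, and "the series" means these few. Any claim that something is new, unique, unknown or untested is made for them only; others in the source may bear on it.

Compound 1 `CCCn1c(=O)[nH]c2nc(-c3ccc(S(=O)(=O)N4CCN(c5ccc(F)cc5)CC4)cc3)[nH]c2c1=O` was tested in an assay on CHO cells for displacement of a labelled ligand from adenosine receptor A2b (Homo sapiens), read by scintillation counting, with a stated time of 75 min, in the presence of a further agent that is not named here (on this read-out lower numbers stand for stronger inhibition and higher numbers for weaker inhibition), and gives 0.644 nM. Going by the values given here, on the two numbers so far, compound 1 stands lowest, with compound 2 `CCCn1c(=O)[nH]c2nc(-c3ccc(S(=O)(=O)N4CCN(c5ccc(C)cc5)CC4)cc3)[nH]c2c1=O` nearest at 0.706 nM; the step of a 1.1-fold higher number from compound 1 to compound 2 (0.04 log units; within the scatter) lies within the scatter, so the two compounds cannot be ranked. Compound 3 `CCCn1c(=O)[nH]c2nc(-c3ccc(S(=O)(=O)N4CCN(c5ccccc5)CC4)cc3)[nH]c2c1=O` has not yet been measured. It differs from compound 1 by hydrogen in place of fluoro on an aromatic carbon, that is, a hydrogen in place of the fluoro on the outer aromatic ring. Among the compounds with values here, the only step that bears on this position, methyl in place of fluoro, moved the number by a 1.1-fold higher number from compound 1 to compound 2 (0.04 log units; within the scatter), which is no change beyond the scatter. Swapping the fluoro for hydrogen at the same place is therefore expected to leave the number essentially where it is. For compound 3 the estimate in this assay is 0.75 nM, between 0.3 nM and 1.8 nM, meaning an expected step of a 1.2-fold higher number from compound 1 to compound 3 (0.07 log units; within the scatter).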

Compound 3, inhibition constant: 0.643 nM
Estimate against measurement, compound 3: 1.2-fold (0.07 log units) above; the measured number falls inside the stated range.
By their numbers in this assay, from the lowest: compounds 3, 1 and 2 (each within the scatter of the next).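

In the assay (this assay), compound 3, which carries a plain phenyl in place of the 4-fluorophenyl, sits level with compound 1 (a 1.0-fold lower number from compound 1 to compound 3 (0.00 log units; within the scatter)) and also with compound 2 (a 1.1-fold lower number from compound 2 to compound 3 (0.04 log units; within the scatter)). The earlier pair showed only that methyl and fluoro could not be told apart at this place; compound 3 adds that, among these three compounds, neither group is needed for a number of this size, since the unsubstituted ring gives the same reading within the scatter. Nothing available here explains why the three compounds read alike.

Hydrogen, fluoro and methyl are the only groups shown at this place on the ring. From the compounds shown here alone, how an amine, a carboxylic acid or a methoxy group there would read remains open, as does the effect of any of them on another receptor.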